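Removing a Chloro Group From a Piperazine-Linked Dithiocarbamate

A few compounds are considered here, and "the series" means these few. Any claim that something is new, unique, unknown or untested is made for them only; others in the source may bear on it.

Of the compounds shown here, two have so far been measured in a functional assay on MGC-803 cells (Homo sapiens) for antiproliferative activity, read by CCK-8 assay, with a stated time of 72 h, tested at 2 uM; on this read-out lower numbers stand for a weaker effect and higher numbers for a stronger effect at the one concentration tested. Compound 1 `Nc1ccccc1NC(=O)c1ccc(CSC(=S)N2CCN(c3ccc(Cl)cc3)CC2)cc1` gives 15% in this assay, the lowest of the two numbers recorded. Compound 2 `CN(Cc1cccnc1)C(=S)SCc1ccc(C(=O)Nc2ccccc2N)cc1` gives 45.9% in this assay, a number that lies beyond the scatter above that of compound 1. The two compounds differ in more than one place, so no single change can be read from the gap between them.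

The next compound to be measured is compound 3 `Nc1ccccc1NC(=O)c1ccc(CSC(=S)N2CCN(c3ccccc3)CC2)cc1`. It differs from compound 1 in one place only (hydrogen in place of chloro on an aromatic carbon). Among the compounds with values here, no pair of measured compounds shows this change, so there is no measured step to lean on. Within the data shown here, with the only anchor being compound 1 at 15%, the expectation is that the step from compound 1 to compound 3 in this assay stays within the scatter, with no clear direction, which is what a number 3 percentage points higher from compound 1 to compound 3 (within the scatter) is meant to express. Compound 3 is therefore estimated at 18% in this assay, within a range from 5% to 35%.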

Compound 3, a percentage reported as inhibition, at one concentration (the size of the read-out at that concentration, not a potency): 42.3%
Estimate against measurement, compound 3: 24.3 percentage points below, and the stated range ends below it.
By their numbers in this assay, from the lowest: compound 1; then compounds 3 and 2 (each within the scatter of the next).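

In this assay, removing the chloro group and leaving hydrogen in its place, so that 4-chlorophenyl becomes phenyl, gives a number 27.3 percentage points higher from compound 1 to compound 3 (beyond the scatter). Within the data shown here, this is the first measured change at this position, and it shows that the position matters: the loss of one heavy atom from an aromatic carbon, para to a large group, moves the read-out beyond the usual scatter, and the phenyl compound gives the stronger effect at the one concentration tested. No measurement shown here explains why the chlorine and the hydrogen differ, so this step can be recorded only as an observation.

On these data alone, with only chloro and hydrogen to compare at this position, it remains open whether the drop belongs to chlorine in particular or would also appear with another group there, such as fluoro, methyl, methoxy or an amine. As far as these compounds go, it is also open whether the same step would hold at other concentrations, since a reading at a single concentration shows the size of the effect there and not a potency.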